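A Trifluoromethyl Swap on a Shared Core

This account rests on a few compounds, and the source may have more. Where it says the series, first, only, none or still open, it means among the compounds named here.

Of the compounds shown here, three have been measured in a functional assay on HeLa cells (Homo sapiens) for inhibition; on this read-out higher numbers stand for weaker inhibition and lower numbers for stronger inhibition. Compound 1 `Cc1cn(/C=C/C=O)c(=O)[nH]c1=O` gives 23000 nM, compound 2 `Nc1ncnc2c1ncn2/C=C/C=O` gives 30000 nM, and compound 3 `O=C/C=C/n1ccc(=O)[nH]c1=O` gives 30000 nM. Compound 3 thus stands level with compound 2, and its gap to compound 1 lies within the scatter, so no order among the three can be claimed. Compound 4 `O=C/C=C/n1cc(C(F)(F)F)c(=O)[nH]c1=O` differs from compound 3 by trifluoromethyl in place of hydrogen on an aromatic carbon. For the measured compounds named here, the only measured step at this place, a 1.3-fold higher number from compound 1 to compound 3 (0.12 log units; within the scatter), was within the scatter, so a methyl and a hydrogen there gave similar numbers. Nothing measured points to a change beyond the scatter at this position. Compound 4 is therefore expected to give 25000 nM, within 8000 nM to 80000 nM, and the step of a 1.2-fold lower number from compound 3 to compound 4 (0.08 log units; within the scatter) is expected to stay within the scatter.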

Compound 4, half-maximal inhibitory concentration: 60000 nM
Compound 4: middle estimate off by 2.4-fold (0.38 log units), on the low side; the measured number falls inside the stated range.
By their numbers in this assay, from the lowest: compounds 1, 2, 3 and 4 (each within the scatter of the next, the first and the last beyond it).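

At this position, trifluoromethyl in place of hydrogen gives a 2.0-fold higher number from compound 3 to compound 4 (0.30 log units; within the scatter) in this assay, so this swap alone cannot be told apart from repeat-to-repeat variation. Trifluoromethyl in place of methyl gives a 2.6-fold higher number from compound 1 to compound 4 (0.42 log units; beyond the scatter), the first step at this position to pass beyond the scatter, though only modestly. No supporting measurement is available to explain this step.

As far as these compounds go, how an amine, a carboxylic acid or a longer chain would read at this position remains open. So does the contribution of the 2-formylethenyl group, which all four compounds carry.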